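This account rests on a few compounds, and the source may have more. Where it says the series, first, only, none or still open, it means among the compounds named here.

Working notes on the series, run in a functional assay on COS-7 cells (Chlorocebus aethiops) for inhibition, read by MTT assay; on this read-out higher numbers stand for weaker inhibition and lower numbers for stronger inhibition. Compound 1 `O=C1Nc2ccc(Br)cc2/C1=N/NC(=S)N/N=C/c1ccc(-c2ccccc2)cc1` gives > 50000 nM, a limit of the assay rather than a number. Compound 2 `O=C1Nc2ccc(Br)cc2/C1=N/NC(=S)N/N=C/c1ccccc1Br` gives > 50000 nM, again only a limit. Compound 3 `Cc1ccc(O)c(/C=N/NC(=S)N/N=C2\C(=O)Nc3ccc(C)cc32)c1` likewise stops at a limit with > 50000 nM. Compound 2 therefore stands where the whole series stands so far, at the limit of > 50000 nM in this assay, at which 3 of the 3 values shown sit. Compound 4 `COc1ccc(/C=N/NC(=S)N/N=C2\C(=O)Nc3ccc(Br)cc32)cc1O` is not yet measured; it carries 3-hydroxy-4-methoxyphenyl in place of 2-bromophenyl on a carbon with a double bond to nitrogen, that is 3-hydroxy-4-methoxyphenyl in place of 2-bromophenyl on a carbon with a double bond to nitrogen. Within the data shown here, no step between two measured compounds exists, so nothing sizes this change. The step of a number no higher from compound 2 to compound 4 (the limit leaves the size open) is expected to be none beyond the scatter, because compound 2 sits at the limit of > 50000 nM in this assay, at which 3 of the 3 values shown sit. Compound 4 is expected near 50000 nM, within 20000 nM to 200000 nM.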

Compound 4, half-maximal inhibitory concentration: 3090 nM
The estimate for compound 4 lay 16-fold (1.21 log units) above the measured number, and the stated range ends above it.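

In this assay, 3-hydroxy-4-methoxyphenyl in place of 2-bromophenyl on a carbon with a double bond to nitrogen gives an at least 16-fold lower number from compound 2 to compound 4 (1.20 log units; beyond the scatter), so the group at this position can move the read-out on the core of compound 2. The step has only a lower bound on its size, since compound 2 is a limit. The series now holds one real number, and the rest stays at a limit: the limit of > 50000 nM in this assay, at which 3 of the 4 values shown sit.

Among these compounds, the single change swaps the whole aryl group, so the shares of the hydroxy group, the methoxy group and the loss of bromine remain unseparated. On these data alone, whether an amine or a carboxylic acid on this phenyl ring would lower the number further remains open.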